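A few compounds are considered here, and "the series" means these few. Any claim that something is new, unique, unknown or untested is made for them only; others in the source may bear on it.

Measured compounds:
compound 1 `C[C@H](C(=O)NCc1ccc(C(F)(F)F)nc1C1CCC(C)(C)CC1)c1ccc(NS(C)(=O)=O)c(F)c1` — 0.3 nM
compound 2 `CC(C(=O)NCc1ccc(C(F)(F)F)nc1C1CCC(C)(C)CC1)c1ccc(NS(C)(=O)=O)c(F)c1` — 0.4 nM

Notes. In an assay on CHO cells for antagonist activity at transient receptor potential cation channel subfamily V member 1 (Homo sapiens), read by FLIPR and calcium flux (on this read-out higher numbers stand for weaker inhibition and lower numbers for stronger inhibition), compound 1 gives 0.3 nM, the lower of the two numbers in hand; compound 2 gives 0.4 nM, and the step of a 1.3-fold higher number from compound 1 to compound 2 (0.12 log units; within the scatter) does not separate them. That step rests only on the fact that one of compounds 1 and 2 is drawn with a defined configuration and the other without, at the place where they differ and says nothing about the ring that sits on the core.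

Compound 3 `C[C@H](C(=O)NCc1ccc(C(F)(F)F)nc1C1=CCC(C(C)(C)C)CC1)c1ccc(NS(C)(=O)=O)c(F)c1` is the compound still to be measured. Its difference from compound 1 is 4-(tert-butyl)cyclohex-1-en-1-yl in place of 4,4-dimethylcyclohexyl on an aromatic carbon. For the measured compounds named here, no measured step touches this position, so there is nothing in the present data to set a direction for the change; the only measured step, a 1.3-fold higher number from compound 1 to compound 2 (0.12 log units; within the scatter), concerns a different place and was within the scatter. The expectation is therefore a step of a 1.7-fold higher number from compound 1 to compound 3 (0.22 log units; within the scatter) of no more than the usual scatter, with some extra width for an untested change. Compound 3 is estimated at 0.5 nM, between 0.15 nM and 2 nM.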

Compound 3, inhibition constant: 0.1 nM
Estimate against measurement, compound 3: 5.0-fold (0.70 log units) above; the whole stated range lies above it.
By their numbers in this assay, from the lowest: compound 3; then compounds 1 and 2 (each within the scatter of the next).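

In this assay, 4-(tert-butyl)cyclohex-1-en-1-yl in place of 4,4-dimethylcyclohexyl on an aromatic carbon gives a 3.0-fold lower number from compound 1 to compound 3 (0.48 log units; beyond the scatter) and this first step at the position lies beyond the scatter, so the read-out here does respond to the group on this carbon. The change is a combined one: the entering group brings a double bond outside aromatic rings and more heavy atoms together, and this single step cannot divide its size between them. Nothing measured on these compounds bears on the reason for the lower number.

Still open, on these data alone, is whether saturated 4-(tert-butyl)cyclohexyl or 4,4-dimethylcyclohex-1-en-1-yl at this position would match the lower number of compound 3. Also open, as far as these compounds go, is how the same position responds to a phenyl ring or to a ring carrying an amine, such as piperidine.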